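Trifluoromethyl removal on the benzoyl of compound 3

This account rests on a few compounds, and the source may have more. Where it says the series, first, only, none or still open, it means among the compounds named here.

Measured so far:
compound 1 `O=C(Nc1cccc(-n2cc(-c3ccncc3)c(-c3ccc(Cl)c(O)c3)n2)c1)Nc1cccc(C(F)(F)F)c1` — 1760 nM
compound 2 `COc1cc(-c2nn(-c3cccc(NC(=O)Nc4cc(C(F)(F)F)cc(C(F)(F)F)c4)c3)cc2-c2ccncc2)ccc1Cl` — 1310 nM
compound 3 `COc1cc(-c2nn(-c3cccc(NC(=O)c4cccc(C(F)(F)F)c4)c3)cc2-c2ccncc2)ccc1Cl` — 1760 nM

In a functional assay on DU-145 cells (Homo sapiens) for inhibition, read by sulforhodamine B assay, with a stated time of 48 h (a lower number here means a stronger inhibitor of growth, a higher number a weaker inhibitor of growth), compound 3 gives 1760 nM. This number is level with that of compound 1, and the two together are the highest of the three; the gap to compound 2, which gives 1310 nM, lies within the scatter. All three numbers therefore sit in one narrow band.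

Compound 4 `COc1cc(-c2nn(-c3cccc(NC(=O)c4ccccc4)c3)cc2-c2ccncc2)ccc1Cl` is not yet measured. It differs from compound 3 by a single change: hydrogen in place of trifluoromethyl on an aromatic carbon. Within the data shown here, no measured pair shows this change, so no step size is known from the data. The expectation is a modest step toward a higher number, possibly no larger than the scatter, shown by a 1.4-fold higher number from compound 3 to compound 4 (0.15 log units; within the scatter). Compound 4 is therefore estimated at 2500 nM, with a range from 1200 nM to 6000 nM.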

Compound 4, concentration for 50% growth inhibition: 780 nM
Estimate against measurement, compound 4: 3.2-fold (0.51 log units) above; the measured number lies below the stated range.
By their numbers in this assay, from the lowest: compounds 4, 2, 1 and 3 (each within the scatter of the next, the first and the last beyond it).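

The trifluoromethyl on the benzoyl of compound 3 is not required for growth inhibition: in this assay, hydrogen in its place gives a 2.3-fold lower number from compound 3 to compound 4 (0.35 log units; beyond the scatter). Among these compounds, this is the first single-place change, and it shows that this aromatic carbon can move the number beyond the scatter, although the three earlier numbers lay in one narrow band. No available evidence bears on the reason for this step.

From the compounds shown here alone, it remains open whether a nitrile, an amine or a carboxylic acid on this carbon would keep, lower or raise the number of compound 4.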